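Shortening the amine substituent from cyclopentyl to methyl

A few compounds are considered here, and "the series" means these few. Any claim that something is new, unique, unknown or untested is made for them only; others in the source may bear on it.

Compound 3 `COc1cc(N)c(Cl)cc1NC(=O)C1CCN(CC2CCCC2)CC1` belongs to a small set of amides built on one shared core, differing only in the group on the amine nitrogen in the ring. In a functional assay on the whole organism for antagonist activity, with Mus musculus as the target (a lower number here means that less compound is needed, a higher number that more compound is needed for the effect), compound 3 gives > 10 mg/kg, which is a limit of the assay and not a number. Compound 1 `COc1cc(N)c(Cl)cc1NC(=O)C1CCN(C2CCCC2)CC1` gives > 10 mg/kg in this assay, again a limit. Compound 2 `CCCCN1CCC(C(=O)Nc2cc(Cl)c(N)cc2OC)CC1` gives > 10 mg/kg in this assay, also a limit. The steps a step that the two limits leave unreadable from compound 1 to compound 2, a step that the two limits leave unreadable from compound 1 to compound 3 and a step that the two limits leave unreadable from compound 2 to compound 3 therefore cannot be read in size because the limit of > 10 mg/kg in this assay, at which 3 of the 3 values shown sit, holds every value in the set at the same edge.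

Compound 4 `CCN1CCC(C(=O)Nc2cc(Cl)c(N)cc2OC)CC1` is the next member. Its change from compound 3 is methyl in place of cyclopentyl on a saturated chain carbon bound to an amine nitrogen in a ring. The measured steps that bear on it are the three just named, and none of them yields a readable size, so no direction beyond the scatter can be derived for the coming step in this assay. The account therefore expects compound 4 to remain at the limit, with a value estimated at 15 mg/kg and a range from 5 mg/kg to 50 mg/kg. The step that the limit leaves unreadable from compound 3 to compound 4 is thus expected to be small.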

Compound 4, dose for half-maximal effect: > 10 mg/kg
Compound 4: only a limit was reported; the forecaster's own chance of this, stated with the estimate: 75%; the middle value lies beyond the limit too.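

Compound 4 sits at the same limit as compound 1, compound 2 and compound 3 in this assay, so none of its steps to those compounds can be read in size: the limit of > 10 mg/kg in this assay, at which 4 of the 4 values shown sit.

The compounds shown leave open whether any group on the amine nitrogen in the ring gives a readable dose in this assay.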